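Adding a bromo group to compound 2

The compounds below may be only part of what the source reports. "The series", "measured", "known", "first", "only" and "open" are said of these compounds alone.

Compound 1 `O=C(Nc1cc(-c2ccccc2)[nH]n1)c1cncc(Br)c1` gives 19300 nM
Compound 2 `O=C(Nc1cc(-c2ccccc2)[nH]n1)c1ccc(Cl)nc1` gives 19000 nM

Both numbers come from a functional assay on WM1361 cells (Homo sapiens) for antiproliferative activity, read by MTT assay, with a stated time of 48 h (on this read-out higher numbers stand for weaker inhibition and lower numbers for stronger inhibition), and they cannot be told apart. Within the data shown here, the one measured step is a 1.0-fold lower number from compound 1 to compound 2 (0.01 log units; within the scatter) and it lies within the scatter, so compound 2 stands level with compound 1 and neither can be ranked above the other.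

Compound 3 `O=C(Nc1cc(-c2ccc(Br)cc2)[nH]n1)c1ccc(Cl)nc1` makes a single change to compound 2 (bromo in place of hydrogen on an aromatic carbon) with bromo in place of hydrogen on an aromatic carbon, turning phenyl into 4-bromophenyl. The measured step altered the group on the carbonyl carbon and left the phenyl untouched, so it bears only indirectly on this change. Among the measured compounds shown here, it shows a swap elsewhere in the molecule with no effect beyond the scatter, but no measured step covers a change on the phenyl. No step beyond the scatter is therefore expected in this assay and the data favour no direction. The estimated change is a 1.2-fold lower number from compound 2 to compound 3 (0.07 log units; within the scatter) and no more. Compound 3 is estimated at 16000 nM with an expected range of 6000 nM to 35000 nM for now.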

Compound 3, half-maximal inhibitory concentration: 19300 nM
The estimate for compound 3 lay 1.2-fold (0.08 log units) below the measured number; the measured number falls inside the stated range.
By their numbers in this assay, from the lowest: compounds 2, 1 and 3 (each within the scatter of the next).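

In this assay, the step from phenyl to 4-bromophenyl is a 1.0-fold higher number from compound 2 to compound 3 (0.01 log units; within the scatter), so compound 3 cannot be told apart from compound 2. Among these compounds, the earlier pair tested only a swap on the carbonyl carbon, whereas this result is the first reading from the phenyl side of the molecule: here, a single bromine atom on an aromatic carbon, para to a large group, produces no step beyond the scatter. Nothing available explains why this bromo group makes no measurable difference in this assay.

The compounds shown leave open whether a different group at this same place, such as an amine, a carboxylic acid or a longer chain like n-butyl, would produce a step beyond the scatter. They also leave open whether bromo would read the same on another carbon of this ring, or with 5-bromopyridin-3-yl in place of 6-chloropyridin-3-yl on the carbonyl carbon.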